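This account rests on a few compounds, and the source may have more. Where it says the series, first, only, none or still open, it means among the compounds named here.

Measured compounds in a functional assay on A549 cells (Homo sapiens) for cytotoxicity, read by MTT assay, with a stated time of 48 h; on this read-out lower numbers stand for stronger inhibition and higher numbers for weaker inhibition:
- compound 1, `COc1cc(-c2nnc3n2NC(c2ccco2)C(C(=O)c2cccc(Br)c2)S3)cc(OC)c1OC`: 36900 nM
- compound 2, `COc1ccc(C(=O)C2Sc3nnc(-c4cc(OC)c(OC)c(OC)c4)n3NC2c2cccs2)cc1`: only a limit, > 100000 nM
- compound 3, `COc1cc(-c2nnc3n2NC(c2cccs2)C(C(=O)c2ccc(Cl)cc2)S3)cc(OC)c1OC`: 20100 nM

Compound 1 stands highest of the two numbers shown; the gap to compound 3 is within the usual scatter, so no order between the two is claimed. For compound 2 the assay gives a limit, not a number (the limit of > 100000 nM in this assay, at which 1 of the 3 values shown sits).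

Going by the values given here, the only measured step, an at least 4.9-fold lower number from compound 2 to compound 3 (0.69 log units; beyond the scatter), changes a substituent on a different aryl group and does not bear on the present step. Compound 4, `COc1cc(-c2nnc3n2NC(c2ccco2)C(C(=O)c2ccc(Br)cc2)S3)cc(OC)c1OC`, differs from compound 1 by 4-bromophenyl in place of 3-bromophenyl on a carbonyl carbon. Among the compounds with values here, no measured step covers a move of a bromine on this ring, so a step within the scatter is expected, a 1.2-fold lower number from compound 1 to compound 4 (0.09 log units; within the scatter). Compound 4 is therefore estimated at 30000 nM, with an expected range of 12000 nM to 80000 nM.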

Compound 4, half-maximal inhibitory concentration: 42100 nM
For compound 4 the middle estimate is 1.4-fold (0.15 log units) below the measured one; the measured number falls inside the stated range.
By their numbers in this assay, from the lowest: compounds 3, 1 and 4 (each within the scatter of the next, the first and the last beyond it). At a limit, above all of these: compound 2.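

In this assay, 4-bromophenyl in place of 3-bromophenyl on a carbonyl carbon gives a 1.1-fold higher number from compound 1 to compound 4 (0.06 log units; within the scatter), so in this pair the place of the bromine makes no difference beyond the scatter. This is the first step shown in which the atoms stay the same and only their joining differs. No measured property shown bears on this step.

Going by these compounds, it remains open whether an amine or a carboxylic acid in place of the bromine would give a step beyond the scatter. Also open, on these data alone, is whether moving the bromine would give the same result on another variant of the shared core.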